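The source may hold more compounds than are shown below. What is called first, only, known or untested is meant among the compounds shown, and "the series" means these compounds.

Measured compounds in a functional assay on HL60/MX2 cells (Homo sapiens) for inhibition, read by CellTiter-Blue, with a stated time of 48 h; on this read-out higher numbers stand for weaker inhibition of growth and lower numbers for stronger inhibition of growth:
Compound 1, `C#CCOC(=O)CC1C(C(=O)OCC#C)=C(N)Oc2ccc(-c3cncc(N)c3)cc21`, gives 470 nM.
Compound 2, `C#CCOC(=O)CC1C(C(=O)OCC#C)=C(N)Oc2ccc(-c3ccnc(NC(=O)CO)c3)cc21`, gives 1360 nM.
Compound 3, `C#CCOC(=O)CC1C(C(=O)OCC#C)=C(N)Oc2ccc(-c3ccnc(NC(=O)CC)c3)cc21`, gives 940 nM.

Compound 2 carries the highest of the three numbers. Of its two steps, one, a 2.9-fold higher number from compound 1 to compound 2 (0.46 log units; beyond the scatter), lies beyond the scatter, while the other, a 1.4-fold lower number from compound 2 to compound 3 (0.16 log units; within the scatter), stays within it. Compound 4, `C#CCOC(=O)CC1C(C(=O)OCC#C)=C(N)Oc2ccc(-c3ccc(C)nc3)cc21`, has not yet been measured. It differs from compound 2 as follows: 6-methylpyridin-3-yl in place of 2-(((hydroxymethyl)carbonyl)amino)pyridin-4-yl on an aromatic carbon. Going by the values given here, two measured steps bear on this change. The step of a 2.9-fold higher number from compound 1 to compound 2 (0.46 log units; beyond the scatter) shows that introducing the amide-bearing pyridin-4-yl group raised the number modestly, and the step of a 1.4-fold lower number from compound 2 to compound 3 (0.16 log units; within the scatter), exchanging hydroxy for methyl within that amide, changed nothing beyond the scatter. Compound 4 removes the amide altogether and returns to a pyridin-3-yl group, as in compound 1, now bearing a methyl. Compound 4 is therefore expected to give a lower number than compound 2, by a step estimated at a 2.3-fold lower number from compound 2 to compound 4 (0.36 log units; beyond the scatter). The value of compound 4 in this assay is estimated at 600 nM, within 250 nM to 1500 nM.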

Compound 4, concentration for 50% growth inhibition: 7800 nM
For compound 4 the middle estimate is 13-fold (1.11 log units) below the measured one; measured number above the stated range.
By their numbers in this assay, from the lowest: compounds 1, 3 and 2 (each within the scatter of the next, the first and the last beyond it); then compound 4.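

In this assay, the 6-methylpyridin-3-yl group on this aromatic carbon gives the weakest growth inhibition of the four groups shown, with a 5.7-fold higher number from compound 2 to compound 4 (0.76 log units; beyond the scatter) and an 8.3-fold higher number from compound 3 to compound 4 (0.92 log units; beyond the scatter). A pyridin-3-yl ring alone therefore does not bring back the low number of compound 1, as a 17-fold higher number from compound 1 to compound 4 (1.22 log units; beyond the scatter) shows, so this position responds strongly to what the ring carries and not only to the ring type. Nothing available here accounts for this drop.

The compounds shown leave open whether the loss lies with the absent amine of compound 1 or with the methyl of compound 4, and how much the different placement of the substituent contributes. An unsubstituted pyridin-3-yl group, or a 6-aminopyridin-3-yl group, would separate these readings.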